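Iodo in place of chloro on the shared core

A few compounds are considered here, and "the series" means these few. Any claim that something is new, unique, unknown or untested is made for them only; others in the source may bear on it.

In a functional assay on MCF7 cells (Homo sapiens) for inhibition (on this read-out higher numbers stand for weaker inhibition and lower numbers for stronger inhibition), compound 1 (`Cc1cc(-c2nc3ccccc3s2)ccc1NS(=O)(=O)O`) gives 490 nM and compound 2 (`O=S(=O)(O)Nc1ccc(-c2nc3ccccc3s2)cc1Cl`) gives 420 nM on the same read-out. Among the compounds with values here, compound 2 therefore stands within the scatter of compound 1, the only other measured compound. Compound 3 (`O=S(=O)(O)Nc1ccc(-c2nc3ccccc3s2)cc1I`) differs from compound 2 by one change, (iodo in place of chloro on an aromatic carbon), ortho to a sulfoamino group. Within the data shown here, the only measured step at this place is a 1.2-fold lower number from compound 1 to compound 2 (0.07 log units; within the scatter) for chloro in place of methyl on an aromatic carbon, and it lies within the scatter. Among the measured compounds shown here, no measured compound carries iodo, so this single step is a thin guide. With only a 1.2-fold lower number from compound 1 to compound 2 (0.07 log units; within the scatter) to go on, no step beyond the scatter is expected in this assay in either direction. The estimate amounts to a 1.1-fold lower number from compound 2 to compound 3 (0.02 log units; within the scatter) as the expected change. For compound 3 the estimated value is 400 nM with an expected range from 170 nM to 950 nM around that estimate.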

Compound 3, half-maximal inhibitory concentration in the MCF7 assay: 1800 nM
Compound 3: middle estimate off by 4.5-fold (0.65 log units), on the low side, and the stated range ends below it.
By their numbers in the MCF7 assay, from the lowest: compounds 2 and 1 (each within the scatter of the next); then compound 3.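

In the MCF7 assay this position proves sensitive to the group it carries: chloro in place of methyl had stayed within the scatter, but iodo gives a 4.3-fold higher number from compound 2 to compound 3 (0.63 log units; beyond the scatter) and a 3.7-fold higher number from compound 1 to compound 3 (0.57 log units; beyond the scatter). Both steps lie beyond the scatter, so among the three groups shown, methyl and chloro read alike and only iodo weakens inhibition. In a physicochemical assay for lipophilicity, measured as octanol-water partition, at pH 7.4 (a lower number here means a more polar compound, a higher number a more lipophilic compound), compound 2 gives 0.02 and compound 3 gives 1.8. The same change raises lipophilicity strongly in the physicochemical assay, which offers one possible link to the weaker inhibition of compound 3, though a single pair cannot establish it: the measured distribution coefficient of compound 2, 0.02, and of compound 3, 1.8, a number 1.78 log units higher (beyond the scatter)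

On these data alone, whether the weaker inhibition tracks that rise or belongs to iodo itself stays open on this one pair. Also open, as far as these compounds go, is how a bromo group or a carboxylic acid at this place would read in the MCF7 assay.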